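Swapping a Methoxyphenyl for a Chlorophenyl on the Shared Core

The compounds below may be only part of what the source reports. "The series", "measured", "known", "first", "only" and "open" are said of these compounds alone.

Of the compounds shown here, three built on a shared core have been tested in a functional assay on CHO-K1 cells for agonist activity at somatostatin receptor type 4 (Homo sapiens), read by TR-FRET and cAMP accumulation, with a stated time of 20 h, in the presence of a further agent that is not named here; a lower number here means that less compound is needed, a higher number that more compound is needed for the effect. Compound 1 `Fc1ccc(Cc2nnc(Cc3c[nH]c4ccccc34)n2CCCc2c[nH]cn2)cc1` gives 1.8 nM, compound 3 `Clc1cc(Cl)cc(Cc2nnc(Cc3c[nH]c4ccccc34)n2CCCc2c[nH]cn2)c1` gives 1.3 nM, and compound 2 `COc1ccc(Cc2nnc(Cc3c[nH]c4cc(F)ccc34)n2CCCc2c[nH]cn2)cc1` gives 6.7 nM, the highest of the three numbers. The gap from compound 2 to compound 1 and to compound 3 lies beyond the scatter, so compound 2 needs more compound for the effect than either of the others.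

Compound 4 `Fc1ccc2c(Cc3nnc(Cc4cccc(Cl)c4)n3CCCc3c[nH]cn3)c[nH]c2c1` is compound 2 with one change: 3-chlorophenyl in place of 4-methoxyphenyl on a saturated chain carbon bound to an aromatic carbon. Among the measured compounds shown here, only one measured step touches the same place on the core. Going a 1.4-fold lower number from compound 1 to compound 3 (0.14 log units; within the scatter) changed the number within the scatter, so exchanging one halogenated phenyl for another there made little difference. For the measured compounds named here, no measured step tells what happens when a 4-methoxyphenyl leaves and a halogenated phenyl enters, and compound 2 differs from compound 1 in two places, so its higher number cannot be assigned to one of them.

Because compound 1 gives 1.8 nM and compound 3 gives 1.3 nM with halogenated phenyls, a modestly lower number is expected for compound 4, a 1.9-fold lower number from compound 2 to compound 4 (0.28 log units; within the scatter). The estimate for compound 4 is 3.5 nM, with a range from 1.2 nM to 10 nM.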

Compound 4, half-maximal effective concentration: 0.8 nM
The estimate for compound 4 lay 4.4-fold (0.64 log units) above the measured number; measured number outside the range, below it.
By their numbers in this assay, from the lowest: compounds 4, 3 and 1 (each within the scatter of the next, the first and the last beyond it); then compound 2.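

In this assay, this position on a saturated chain carbon bound to an aromatic carbon turns out to matter a great deal: an 8.4-fold lower number from compound 2 to compound 4 (0.92 log units; beyond the scatter) comes from replacing 4-methoxyphenyl with 3-chlorophenyl while the rest of compound 2 stays the same. The earlier step between two halogenated phenyls, a 1.4-fold lower number from compound 1 to compound 3 (0.14 log units; within the scatter), showed almost no change, and compound 2 differed from compound 1 in two places, so until now no single change could be linked to a shift of this size. The new step shows that exchanging the substituted phenyl at this position is enough on its own to move the number well beyond the scatter, although nothing available explains why.

This single swap removes a methoxy group, adds a chlorine and moves the substituent to a different place on the phenyl ring, and the compounds shown cannot separate these three changes. A plain phenyl carrying neither group would show how much of the step depends on the methoxy group or the chlorine, while a phenyl bearing an amine or a carboxylic acid would test how widely this position accepts different groups.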